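Swapping a dihydroxyphenyl for a quinone ring

The source may hold more compounds than are shown below. What is called first, only, known or untested is meant among the compounds shown, and "the series" means these compounds.

Of the compounds shown here, three sharing one core have been tested in a functional assay on cells (Melanoma cell, Homo sapiens) for cytotoxicity, read by sulforhodamine B assay, with a stated time of 48 h; a lower number here means a stronger inhibitor of growth, a higher number a weaker inhibitor of growth. Compound 1 `COc1ccc(OC)c(-c2cc(-c3ccccc3)nn2-c2ccc(S(=O)(=O)NC(C)=O)cc2)c1` gives 36200 nM. Compound 2 `CC(=O)NS(=O)(=O)c1ccc(-n2nc(-c3ccccc3)cc2-c2cc(O)ccc2O)cc1` gives 100000 nM, and compound 3 `CC(=O)NS(=O)(=O)c1ccc(-n2nc(-c3ccc(Cl)cc3)cc2-c2cc(O)ccc2O)cc1` gives 60100 nM. Going by the values given here, compound 2 thus has the highest number of the three, yet the gap to compound 3 lies within the scatter, and only the step to compound 1 stands beyond it. The step from compound 1 to compound 2 was a 2.8-fold higher number from compound 1 to compound 2 (0.44 log units; beyond the scatter), while the step from compound 2 to compound 3 was a 1.7-fold lower number from compound 2 to compound 3 (0.22 log units; within the scatter).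

Compound 4 `CC(=O)NS(=O)(=O)c1ccc(-n2nc(-c3ccccc3)cc2C2=CC(=O)C=CC2=O)cc1` has not yet been tested. It differs from compound 2 in one place: a group of 8 heavy atoms (6 carbon, 2 oxygen; one six-membered non-aromatic ring of carbon only) in place of a group of 8 heavy atoms (6 carbon, 2 oxygen; one six-membered aromatic ring of carbon only), on an aromatic carbon. Neither measured step touches this kind of change; one altered the same ring's substituents, the other a distant phenyl group, so neither is a guide here. On that basis, the expected change in this assay is modest: compound 4 is estimated at 30000 nM, with a likely range from 8000 nM to 100000 nM. The expected step from compound 2 to compound 4 is a 3.3-fold lower number from compound 2 to compound 4 (0.52 log units; beyond the scatter).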

Compound 4, concentration for total growth inhibition: 100000 nM
For compound 4 the middle estimate is 3.3-fold (0.52 log units) below the measured one, and the stated range covers the measured number.
By their numbers in this assay, from the lowest: compounds 1, 3, 2 and 4 (each within the scatter of the next, the first and the last beyond it).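

In this assay, replacing the 2,5-dihydroxyphenyl group with the non-aromatic six-membered ring, which has 0 hydrogen-bond donors in place of 2, gives no change at the digits printed from compound 2 to compound 4 (within the scatter), so among these compounds neither the aromatic ring nor those donors at this carbon changes the number beyond the scatter. The non-aromatic ring also stands apart from the 2,5-dimethoxyphenyl group, with a 2.8-fold higher number from compound 1 to compound 4 (0.44 log units; beyond the scatter), so it sits with the dihydroxy compound rather than the dimethoxy one. Nothing available explains why either step came out this way.

Every group shown at this carbon is a six-membered carbon ring bearing oxygen, so an amine or a carboxylic acid there remains an open test. Also open, on these data alone, is whether the non-aromatic ring would behave the same alongside the chloro group of compound 3.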